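The source may report more compounds than this note shows. Statements on the series, on what has been measured and on what is new or still open speak of the compounds shown alone.

Working notes on the series. The shared core is carried by compound 1, `CC1(C)c2[nH]nc(NC(=O)c3ccccc3)c2CN1Cc1cccc(F)c1F`, and by compound 2, `CN(C)c1cccc(C(=O)Nc2n[nH]c3c2CN(Cc2cccc(F)c2F)C3(C)C)c1`. Among the compounds with values here, in an assay on Sf21 cells for inhibition of high affinity nerve growth factor receptor (Homo sapiens), read by HTRF, with a stated time of 30 min, in the presence of a further agent that is not named here (a higher number here means a weaker inhibitor, a lower number a stronger inhibitor), compound 1 gives 200 nM, and compound 2 gives 420 nM; compound 2 thus holds the higher of the two numbers, the single measured step being a 2.1-fold higher number from compound 1 to compound 2 (0.32 log units; beyond the scatter). Compound 3, `CN1CCN(c2cccc(C(=O)Nc3n[nH]c4c3CN(Cc3cccc(F)c3F)C4(C)C)c2)CC1`, has not been measured. It differs from compound 2 by 4-methylpiperazin-1-yl in place of dimethylamino on an aromatic carbon, the entering group sitting on an aromatic carbon of a six-membered aromatic ring of carbon only, meta to a large group. Within the data shown here, the only measured step bearing on this position is a 2.1-fold higher number from compound 1 to compound 2 (0.32 log units; beyond the scatter), in which placing dimethylamino on that carbon went with a modest rise. Among the measured compounds shown here, no measured pair shows what enlarging that substituent further does, so the expected step is a 1.3-fold higher number from compound 2 to compound 3 (0.12 log units; within the scatter), little change or a slight further rise in this assay. Compound 3 is therefore estimated at 550 nM, with a range from 200 nM to 1500 nM.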

Compound 3, half-maximal inhibitory concentration: 210 nM
The estimate for compound 3 lay 2.6-fold (0.42 log units) above the measured number; low and high end bracket the measured number.
By their numbers in this assay, from the lowest: compounds 1, 3 and 2 (each within the scatter of the next, the first and the last beyond it).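

In this assay, the step from dimethylamino to the larger 4-methylpiperazin-1-yl group on this aromatic carbon is a 2.0-fold lower number from compound 2 to compound 3 (0.30 log units; within the scatter), so enlarging the substituent and adding a six-membered non-aromatic ring does not go with a further rise in the number. Set against hydrogen on the same carbon, the group gives a 1.1-fold higher number from compound 1 to compound 3 (0.02 log units; within the scatter), which shows that this carbon can carry 4-methylpiperazin-1-yl with no change beyond the scatter, unlike dimethylamino, the only one of the two groups whose step from hydrogen lies beyond it. Nothing available offers an explanation for this result.

The compounds shown leave open how much of this depends on the ring and how much on its second nitrogen or the methyl group. A morpholine, a piperidine or an unmethylated piperazine on the same carbon would separate these features.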